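Ethyl ester pyrazoles: swapping the warhead and its position

A few compounds are considered here, and "the series" means these few. Any claim that something is new, unique, unknown or untested is made for them only; others in the source may bear on it.

Compound 2 `CCOC(=O)c1cc(-c2ccc(Oc3ccccc3)cc2)nn1Cc1cccc(NC(=O)CCl)c1` gives the only numerical result in this set: in a functional assay on Maver1 cells (Homo sapiens) for inhibition, read by luminescence and CellTiter-Glo, with a stated time of 72 h (a higher number here means a weaker inhibitor, a lower number a stronger inhibitor), compound 2 gives 500 nM. Compound 1 `C=CC(=O)Nc1ccc(Cn2nc(-c3ccc(Oc4ccccc4)cc3)cc2C(=O)O)cc1` reaches only a limit of the assay, since in this assay compound 1 gives > 60000 nM, as recorded in the limit of > 60000 nM in this assay, at which 1 of the 2 values shown sits. Compound 3 `C=CC(=O)Nc1ccc(Cn2nc(-c3ccc(Oc4ccccc4)cc3)cc2C(=O)OCC)cc1` differs from compound 2 by 4-((vinylcarbonyl)amino)phenyl in place of 3-(((chloromethyl)carbonyl)amino)phenyl on a saturated chain carbon bound to an aromatic nitrogen. Within the data shown here, with no measured step to guide it, a moderate loss beyond the scatter is expected, a 4.0-fold higher number from compound 2 to compound 3 (0.60 log units; beyond the scatter). Compound 3 is therefore estimated at 2000 nM, within 500 nM to 10000 nM.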

Compound 3, half-maximal inhibitory concentration: 13300 nM
Beside the measured number, compound 3's estimate is 6.7-fold (0.82 log units) below it; the measured number lies above the stated range.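

In this assay, 4-((vinylcarbonyl)amino)phenyl in place of 3-(((chloromethyl)carbonyl)amino)phenyl on a saturated chain carbon bound to an aromatic nitrogen proves a large change (a 27-fold higher number from compound 2 to compound 3 (1.42 log units; beyond the scatter)). Ethyl in place of hydrogen on an oxygen next to a carbonyl group also counts (an at least 4.5-fold lower number from compound 1 to compound 3 (0.65 log units; beyond the scatter)). That step is only a bound, since compound 1 stands at a limit of the assay: the limit of > 60000 nM in this assay, at which 1 of the 3 values shown sits.

On these data alone, the step to compound 3 changes the warhead and its position together, so the share of each stays open. As far as these compounds go, whether 3-((vinylcarbonyl)amino)phenyl or a methyl ester would behave alike also remains open.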